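Methoxy for methyl on the aryl ring of compound 2

The compounds below may be only part of what the source reports. "The series", "measured", "known", "first", "only" and "open" are said of these compounds alone.

The series is assessed in an assay on CHO cells with Alpha-1A adrenergic receptor (Homo sapiens) as the target; a higher number here means a weaker inhibitor, a lower number a stronger inhibitor. Of the compounds shown here, three have numbers so far. Compound 1 `O=C1c2ccccc2C(=O)N1CCCCN1CCC(n2c(O)nc3ccccc32)CC1` gives 0.28 nM. Compound 2 `Cc1ccc2c(c1)oc(=O)n2C1CCN(CCCCN2C(=O)c3ccccc3S2(=O)=O)CC1` gives 3.1 nM. Compound 3 `Cc1cc(C)c2oc(=O)n(C3CCN(CCCCN4C(=O)c5ccccc5S4(=O)=O)CC3)c2c1` gives 20 nM. Among these three numbers compound 2 stands second highest: compound 3, with its 20 nM, has the higher number, a gap described as beyond the scatter, and compound 1, with its 0.28 nM, has the lower number, also beyond the scatter. Compound 2 is thus neither the strongest nor the weakest of the three in this assay.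

Compound 4 `COc1ccc2c(c1)oc(=O)n2C1CCN(CCCCN2C(=O)c3ccccc3S2(=O)=O)CC1` has not yet been measured in this assay. It differs from compound 2 in one place: methoxy in place of methyl on an aromatic carbon. Within the data shown here, no pair of measured compounds shows this exchange, so its effect is not known from the data. A small step from compound 2 to compound 4 is expected, of the size a 1.1-fold higher number from compound 2 to compound 4 (0.05 log units; within the scatter), not clearly beyond the scatter in either direction. Compound 4 is therefore estimated to give about 3.5 nM in this assay, with a likely range from 1 nM to 12 nM.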

Compound 4, inhibition constant: 499 nM
Estimate against measurement, compound 4: 140-fold (2.15 log units) below; the whole stated range lies below it.
By their numbers in this assay, from the lowest: compound 1; then compound 2; then compound 3; then compound 4.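

In this assay, methoxy in place of methyl on this aromatic carbon, meta to a fused ring and para to a fused ring, brings a 160-fold higher number from compound 2 to compound 4 (2.21 log units; beyond the scatter). Among these compounds, the earlier compounds offered no pair differing in one place, so this is the first single exchange to be read, and it shows that this position is highly sensitive to the group it carries, even though the exchange adds only one oxygen to the substituent. No measurement among the data accounts for the size of this step.

Going by these compounds, it remains open whether the oxygen or the larger group matters here, a question that ethyl or hydroxy on the same carbon would address. On these data alone, whether the exchange would have a similar effect on the core of compound 1 also remains open.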